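The source may report more compounds than this note shows. Statements on the series, on what has been measured and on what is new or still open speak of the compounds shown alone.

In a functional assay on NALM-6 cells (Homo sapiens) for cytotoxicity, read by MTT assay, with a stated time of 46 h (on this read-out higher numbers stand for weaker inhibition and lower numbers for stronger inhibition), compound 2 `O=C1/C(=C\c2ccncc2)C(c2ccccc2)Oc2ccccc21` gives 700 nM, the lowest of the three numbers recorded, while compound 1 `O=C1/C(=C/c2ccncc2)C(c2ccccc2)Oc2ccccc21` gives 1600 nM and compound 3 `O=C1/C(=C/c2ccc(Cl)cc2)C(c2ccccc2)Oc2ccccc21` gives 7400 nM. Compound 4 `O=C1/C(=C\c2ccc(Br)cc2)C(c2ccccc2)Oc2ccccc21` differs from compound 2 by 4-bromophenyl in place of pyridin-4-yl on a double-bonded chain carbon bound to a double-bonded ring carbon. The step that bears on this change is a 4.6-fold higher number from compound 1 to compound 3 (0.67 log units; beyond the scatter), where pyridin-4-yl likewise gave way to a 4-chlorophenyl; the step of a 2.3-fold lower number from compound 1 to compound 2 (0.36 log units; beyond the scatter) only concerns the double-bond geometry that compound 2 and compound 4 share. A weakening of similar size is therefore expected for compound 4 in this assay, with its number expected to move a 4.3-fold higher number from compound 2 to compound 4 (0.63 log units; beyond the scatter). Compound 4 is accordingly estimated at 3000 nM, within a range from 1200 nM to 8000 nM.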

Compound 4, half-maximal inhibitory concentration: > 1000000 nM
Compound 4 was reported as a limit; the forecaster's own chance of this, stated with the estimate: 5%; middle value at least 330-fold (2.52 log units) from the limit.
By their numbers in this assay, from the lowest: compound 2; then compound 1; then compound 3. At a limit, above all of these: compound 4.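

In this assay the value of compound 4, > 1000000 nM, is a limit and not a number. Even so, an at least 1400-fold higher number from compound 2 to compound 4 (3.15 log units; beyond the scatter) shows that replacing pyridin-4-yl at this position can cost far more than a 4.6-fold higher number from compound 1 to compound 3 (0.67 log units; beyond the scatter) seen earlier, so the change does not have one size across these two pairs. The step itself is only a bound: the limit of > 1000000 nM in this assay, at which 1 of the 4 values shown sits.

As far as these compounds go, whether its size belongs to the 4-bromophenyl group alone or to that group paired with this double-bond geometry stays open. So does how a 4-aminophenyl group would read in the same place.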